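The source may hold more compounds than are shown below. What is called first, only, known or untested is meant among the compounds shown, and "the series" means these compounds.

Three measured compounds share one core and differ only in the group carried on the sulfonyl sulfur. Compound 3 is `COc1ccc(-c2cc(=O)c3c(OC)cc(OC)cc3n2S(=O)(=O)c2ccc(Cl)cc2)cc1`. In a functional assay on KOPN-8 cells (Homo sapiens) for antiproliferative activity, with a stated time of 72 h (a higher number here means that more compound is needed for the effect, a lower number that less compound is needed), compound 3 gives only a limit, > 34400 nM. Compound 1 is `COc1ccc(-c2cc(=O)c3c(OC)cc(OC)cc3n2S(=O)(=O)c2ccc(C=O)cc2)cc1`. In this assay compound 1 likewise gives a limit, > 34400 nM. Compound 2 is `COc1ccc(-c2cc(=O)c3c(OC)cc(OC)cc3n2S(=O)(=O)c2cccc([N+](=O)[O-])c2)cc1`. In this assay compound 2 also gives a limit, > 39600 nM. The step that the two limits leave unreadable from compound 1 to compound 3 therefore cannot be read, and the same holds for a step that the two limits leave unreadable from compound 2 to compound 3 and a step that the two limits leave unreadable from compound 1 to compound 2. Where compound 3 stands is thus known only as the limit of > 34400 nM in this assay, at which 2 of the 3 values shown sit, and the remaining value sits at the limit of > 39600 nM in this assay, at which 1 of the 3 values shown sits.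

Compound 4 is `COc1ccc(-c2cc(=O)c3c(OC)cc(OC)cc3n2S(=O)(=O)c2ccc(Br)cc2)cc1`. The change from compound 3 is bromo in place of chloro on an aromatic carbon. Among the measured compounds shown here, none of the measured steps gives a readable size, so nothing here points toward a shift beyond the scatter in either direction. The expected step is a step that the limit leaves unreadable from compound 3 to compound 4. For compound 4 the estimate in this assay is 50000 nM, with a range from 20000 nM to 120000 nM, and most likely the assay will again report only a limit.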

Compound 4, half-maximal effective concentration: > 86200 nM
Compound 4: only a limit was reported; the forecaster's own chance of this, stated with the estimate: 85%; middle value at least 1.7-fold (0.23 log units) away from the limit.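

Compound 4, like compound 1, compound 2 and compound 3, gives only a limit in this assay, so none of its steps to those three compounds can be read. The compounds shown leave open at what concentration any of the four reaches its half-maximal effect, and so whether changing the group on the sulfonyl sulfur matters.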